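Capping a Phenol Hydroxyl at Compound 3

The source may report more compounds than this note shows. Statements on the series, on what has been measured and on what is new or still open speak of the compounds shown alone.

Compound 1 `C=C[C@@](C)(/C=C/c1ccc(OC(=O)CCCCC)cc1)CCC=C(C)C`: 50%
Compound 2 `COc1ccc(/C=C/[C@@](C)(/C=C/c2ccc(O)cc2)CCC=C(C)C)cc1`: 20%
Compound 3 `CC(C)=CCCC(C)(/C=C/c1ccc(O)cc1)/C=C/c1ccc(O)cc1`: 32%

In a functional assay on HeLa cells (Homo sapiens) for inhibition, with a stated time of 48 h, tested at 50 uM (a lower number here means less inhibition of growth, a higher number more inhibition of growth at the concentration tested), compound 3 holds the middle place of the three numbers, with compound 2 nearest to it and compound 1 furthest. Compound 4 `COc1ccc(/C=C/[C@](C)(/C=C/c2ccc(O)cc2)CCC=C(C)C)cc1` differs from compound 3 by methyl in place of hydrogen on an oxygen on an aromatic ring. Among the compounds with values here, one measured step bears on this change: a number 12 percentage points higher from compound 2 to compound 3 (beyond the scatter), which is modest and runs the opposite way, with hydrogen in place of methyl. Within the data shown here, compound 4 carries the same groups as compound 2 but has the opposite configuration at its stereocentre, and no measured pair shows what that configuration does in this assay. A drop of similar size is therefore expected, with added uncertainty. The expected step is a number 11 percentage points lower from compound 3 to compound 4 (beyond the scatter). For compound 4 the estimated value is 21%, with an expected range from 8% to 35%.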

Compound 4, percent growth inhibition at one concentration: 78%
Compound 4: the middle estimate sits 57 percentage points below what was measured, outside the stated range (above it).
By their numbers in this assay, from the lowest: compound 2; then compound 3; then compound 1; then compound 4.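

In this assay, methyl in place of hydrogen on the oxygen on the aromatic ring does not lower the number, as it gives a number 46 percentage points higher from compound 3 to compound 4 (beyond the scatter), while the reverse change gave a number 12 percentage points higher from compound 2 to compound 3 (beyond the scatter). The same methyl thus goes with a lower number in compound 2 and a higher one in compound 4, so its effect at this position has no single direction across these compounds. The stereocentre at the saturated chain carbon matters at least as much as the capping group, with a number 58 percentage points higher from compound 2 to compound 4 (beyond the scatter), and this gap can be assigned to configuration: the fact that compounds 2 and 4 differ only in the configuration as drawn

The compounds shown leave open whether the S configuration keeps this high number with an ethyl group or a longer chain on the oxygen, or with an amine in its place. Also open, on these data alone, is how the two configurations compare at other concentrations.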